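The source may report more compounds than this note shows. Statements on the series, on what has been measured and on what is new or still open speak of the compounds shown alone.

Measured so far in an ADME assay on a cell-free system (plasma, Homo sapiens); a lower number here means a smaller unbound share, a higher number a larger unbound share of the compound:
- compound 1 `C=CCNC(=O)Nc1nc2cc(-c3cccnc3)c(=O)n(CCC(C)C)c2s1`: 0.03
- compound 2 `CCNC(=O)Nc1nc2cc(-c3cccnc3)c(=O)n(CCC(C)C)c2s1`: 0.06

Compound 2 differs from compound 1 at one place, with methyl in place of vinyl on a saturated chain carbon bound to an amide-type nitrogen. For the measured compounds named here, the measured step is small (a 2.0-fold higher number from compound 1 to compound 2 (0.30 log units; within the scatter)), so compound 2 stands level with its only neighbour as far as this assay can tell.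

Compound 3 `CCNC(=O)Nc1nc2cc(-c3cccnc3)c(=O)n(C(C)C(=O)O)c2s1` departs from compound 2 at another place: 1-carboxyethyl in place of isopentyl on an aromatic nitrogen. In words, this is 1-carboxyethyl in place of isopentyl on an aromatic nitrogen. Going by the values given here, the one measured step lies elsewhere in the structure and within the scatter, so it gives no size for this change. Among the compounds with values here, no measured pair varies the group on that nitrogen, and the expectation therefore rests on the structural change alone, with low confidence. A step beyond the scatter toward a larger unbound share is expected, though not a large one, and the range is kept wide. The expected step is a 2.2-fold higher number from compound 2 to compound 3 (0.34 log units; beyond the scatter) in this assay as an estimate. For compound 3 the estimated value is 0.13 with an expected range from 0.04 to 0.35 as the working figure.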

Compound 3, unbound fraction: 0.22
Beside the measured number, compound 3's estimate is 1.7-fold (0.23 log units) below it; measured number inside the range.
By their numbers in this assay, from the lowest: compounds 1 and 2 (each within the scatter of the next); then compound 3.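

For the compounds shown here, the group on the aromatic nitrogen is the first place where a change moves this assay beyond the scatter: 1-carboxyethyl in place of isopentyl gives a 3.7-fold higher number from compound 2 to compound 3 (0.56 log units; beyond the scatter), a clearer separation than the one earlier step could show. The leaving and entering groups have the same heavy-atom count, so this step comes without a change in that count, while the entering group brings oxygen, a hydrogen-bond donor, a hydrogen-bond acceptor and a double bond outside aromatic rings that isopentyl lacks. The data at hand offer no account of which of these features goes with the step.

Compound 3 alters the carbon chain and introduces the carboxylic acid in a single change, so the compounds shown do not separate the two, and a methyl ester, a primary amide or a plain isopropyl group on the same nitrogen would bear on that question. Also open, on these data alone, is whether 1-carboxyethyl would give a step of similar size on the core of compound 1, and how a longer chain ending in a carboxylic acid would compare.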